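Series notes: fluoro step from compound 1 to compound 3

The source may hold more compounds than are shown below. What is called first, only, known or untested is meant among the compounds shown, and "the series" means these compounds.

Measured so far:
compound 1 `O=C1C(=O)N(Cc2ccc(-c3ccccc3)cc2)c2ccc(OC(F)(F)F)cc21` — < 60%
compound 2 `O=C1C(=O)N(Cc2ccc(Oc3ccccn3)cc2)c2ccc(OC(F)(F)F)cc21` — 46%

In a functional assay on CHO cells for positive allosteric modulation of muscarinic acetylcholine receptor M5 (Homo sapiens), read by FLIPR and calcium flux, with a stated time of 1 h (on this read-out higher numbers stand for larger maximal responses and lower numbers for smaller maximal responses), compound 1 is known only as a limit, < 60%. Compound 2 gives 46% in this assay. The size of the step that the limit leaves unreadable from compound 1 to compound 2 cannot be read, owing to the limit of < 60% in this assay, at which 1 of the 2 values shown sits.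

Compound 3 `O=C1C(=O)N(Cc2ccc(-c3ccccc3)cc2F)c2ccc(OC(F)(F)F)cc21` differs from compound 1 by fluoro in place of hydrogen on an aromatic carbon. Among the compounds with values here, no measured step touches this change: the single measured step, from compound 1 to compound 2, concerns a different part of the molecule and is itself unreadable. The data therefore give no direction for the fluoro step, and compound 1 itself stands only as a limit in this assay. For compound 3 the expected step is a step that the limit leaves unreadable from compound 1 to compound 3, which is expected to stay within the scatter. Compound 3 is estimated at 45% in this assay, with a range from 20% to 65%.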

Compound 3, largest response reached (Emax), in percent of the reference or control that the assay uses: 63%
Beside the measured number, compound 3's estimate is 18 percentage points below it, within the range that was stated.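

Fluoro on the aromatic carbon ortho to a large group and meta to a phenyl group gives the series its first readable step, and in this assay that step is a number at least 3 percentage points higher from compound 1 to compound 3 (that floor lies within the scatter); with that floor, this change shows no loss of maximal response, though it does not establish a real gain. Compound 1 is known only as a limit, < 60%. The true size of the fluoro step stays open, and the step to compound 2 cannot be read at all: the limit of < 60% in this assay, at which 1 of the 3 values shown sits.

The compounds shown leave open how chloro, methoxy or a nitrile on this same carbon would read against fluoro. They also leave open whether fluoro on this carbon would give a comparable result with the (pyridin-2-yl)oxy group of compound 2 in place of phenyl.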